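Branching the Propyl Chain of Compound 3

A few compounds are considered here, and "the series" means these few. Any claim that something is new, unique, unknown or untested is made for them only; others in the source may bear on it.

Compound 3 `CCCN(CC1CC1)c1cc(C)nc2c(-c3ccc(Cl)cc3Cl)nn(C)c12` has the lowest number of the three compounds tested in an assay on HEK293 cells for displacement of a labelled ligand from corticotropin-releasing factor receptor 1 (Homo sapiens); a higher number here means a weaker inhibitor, a lower number a stronger inhibitor: compound 3 gives 1.7 nM, while compound 1 `CCCN(CC)c1cc(C)nc2c(-c3ccc(Cl)cc3Cl)nn(C)c12` gives 4.1 nM and compound 2 `CCN(CC1CC1)c1cc(C)nc2c(-c3ccc(Cl)cc3Cl)nn(C)c12` gives 4.4 nM. Compound 4 `Cc1cc(N(CC(C)C)CC2CC2)c2c(n1)c(-c1ccc(Cl)cc1Cl)nn2C` differs from compound 3 by methyl in place of hydrogen on a saturated chain carbon bound to two saturated chain carbons, that is, propyl becomes isobutyl. Two earlier steps altered the same amino group: lengthening one chain gave a 2.6-fold lower number from compound 2 to compound 3 (0.41 log units; beyond the scatter), and enlarging the other gave a 2.4-fold lower number from compound 1 to compound 3 (0.38 log units; beyond the scatter). Both were modest, and a single added methyl is a small alteration, so compound 4 is expected to shift by a 1.2-fold higher number from compound 3 to compound 4 (0.07 log units; within the scatter), probably within the scatter. The estimate for compound 4 is 2 nM, with a range from 0.8 nM to 5 nM.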

Compound 4, inhibition constant: 3.7 nM
Compound 4: middle estimate off by 1.9-fold (0.27 log units), on the low side; low and high end bracket the measured number.
By their numbers in this assay, from the lowest: compound 3; then compounds 4, 1 and 2 (each within the scatter of the next).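

Adding one methyl to the propyl chain of compound 3 does not extend the earlier gains, and the result is a step in the opposite direction (a 2.2-fold higher number from compound 3 to compound 4 (0.34 log units; beyond the scatter)) in this assay. The isobutyl group leaves compound 4 no better than the smaller amino groups, as the two remaining steps show (a 1.2-fold lower number from compound 2 to compound 4 (0.08 log units; within the scatter); a 1.1-fold lower number from compound 1 to compound 4 (0.04 log units; within the scatter)), while compound 3 keeps the lowest number of the four. Nothing available here explains why this added methyl raises the number.

Still open, going by these compounds, is how a butyl or a methoxyethyl chain in place of propyl would read in this assay. Whether the rise comes from branching itself or from the added carbon also stays unsettled.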